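This account rests on a few compounds, and the source may have more. Where it says the series, first, only, none or still open, it means among the compounds named here.

Compound 1, `COc1ccc2occ(CSC(=S)N(C(C)C)C(C)C)c(=O)c2c1`, is the reference point here. In a functional assay on MDA-MB-435S cells (Homo sapiens) for antiproliferative activity, read by MTT assay, with a stated time of 72 h (a higher number here means a weaker inhibitor, a lower number a stronger inhibitor), compound 1 gives 1800 nM. For the measured compounds named here, only one other compound has been measured: compound 2, `CC(C)N(C(=S)SCc1coc2ccccc2c1=O)C(C)C`, which in this assay gives 7900 nM. The two differ in one spot, a hydrogen in place of the methoxy on an aromatic carbon, and the step of a 4.4-fold higher number from compound 1 to compound 2 (0.64 log units; beyond the scatter). Going by the values given here, of the two numbers so far, compound 1 holds the lower one, so it is the stronger inhibitor of the pair.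

Compound 3, `COc1ccc2occ(CSC(=S)N3CCCCC3)c(=O)c2c1`, is not yet measured. It differs from compound 1 at the other end of the molecule: piperidin-1-yl in place of diisopropylamino on a thiocarbonyl carbon. Among the compounds with values here, the only measured step concerns the aromatic ring and leaves the amine portion untouched, so no measured step speaks directly to this change. The change swaps one ring-free amine for a ring-bearing one of nearly the same size, without altering donors or acceptors, so a step of modest size at most is expected in this assay, with no clear direction. Compound 3 is therefore estimated at 2500 nM, with a range from 800 nM to 8000 nM, meaning an expected step of a 1.4-fold higher number from compound 1 to compound 3 (0.14 log units; within the scatter).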

Compound 3, half-maximal inhibitory concentration: 930 nM
For compound 3 the middle estimate is 2.7-fold (0.43 log units) above the measured one, within the range that was stated.
By their numbers in this assay, from the lowest: compounds 3 and 1 (each within the scatter of the next); then compound 2.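

In this assay, for the compounds shown here, putting piperidin-1-yl in place of diisopropylamino on the thiocarbonyl carbon gives a 1.9-fold lower number from compound 1 to compound 3 (0.29 log units; within the scatter) and so offers the first reading at this end of the molecule, as the earlier pair differed only on the aromatic ring. Compound 1 and compound 3 cannot be told apart in this assay, so a ring-free amine group and one with a six-membered non-aromatic ring are equally acceptable here, at least for this one pair; by contrast, the step at the methoxy, a 4.4-fold higher number from compound 1 to compound 2 (0.64 log units; beyond the scatter), lies beyond the scatter. No measurement is available that could explain why this swap leaves the reading within the scatter.

Still open, going by these compounds, is whether the amine end would accept other groups just as well, such as the smaller pyrrolidine ring, morpholine with its added ring oxygen, or a plain dimethylamino group. Also open, on these data alone, is whether the methoxy would matter as much with piperidin-1-yl in place, as its step is known only with diisopropylamino on the thiocarbonyl carbon.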